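The source may hold more compounds than are shown below. What is called first, only, known or untested is meant among the compounds shown, and "the series" means these compounds.

Measured in a functional assay on HepG2 cells (Homo sapiens) for inhibition, read by MTT assay, with a stated time of 72 h, tested at 50 uM; a lower number here means less inhibition of growth, a higher number more inhibition of growth at the concentration tested:
Compound 1 `C=CCc1ccc(OCc2cn(-c3ccc(C#N)cc3)nn2)c(O)c1`: 12.1%
Compound 2 `C=CCc1ccc(OCc2cn(-c3ccccc3Cl)nn2)c(O)c1`: 4.7%
Compound 3 `C=CCc1ccc(OCc2cn(-c3ccc(OC)cc3)nn2)c(O)c1`: 49.9%

Compound 3 stands highest of the three, clear of both others. Compound 4 `C=CCc1ccc(OCc2cn(-c3cccc(C#N)c3)nn2)c(O)c1` keeps the shared core but carries 3-cyanophenyl in place of 4-methoxyphenyl on an aromatic nitrogen. The closest evidence is a large step, a number 37.8 percentage points higher from compound 1 to compound 3 (beyond the scatter), where methoxy replaces cyano, so the change to compound 4 runs roughly the opposite way. The step of a number 45.2 percentage points higher from compound 2 to compound 3 (beyond the scatter) is also large, while a number 7.4 percentage points lower from compound 1 to compound 2 (within the scatter) shows that the two compounds lacking methoxy stay close. Among the compounds with values here, no 3-cyanophenyl compound has been measured, so the size remains uncertain. A large fall is expected, a number 34.9 percentage points lower from compound 3 to compound 4 (beyond the scatter). For compound 4 the estimated value is 15%, with an expected range from 3% to 35%.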

Compound 4, percent growth inhibition at one concentration: 3.4%
For compound 4 the middle estimate is 11.6 percentage points above the measured one, and the stated range covers the measured number.
By their numbers in this assay, from the lowest: compounds 4, 2 and 1 (each within the scatter of the next); then compound 3.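

With 3-cyanophenyl in place of 4-methoxyphenyl on this aromatic nitrogen, the result is a number 46.5 percentage points lower from compound 3 to compound 4 (beyond the scatter). Against the other two compounds lacking methoxy, 3-cyanophenyl gives a number 8.7 percentage points lower from compound 1 to compound 4 (within the scatter) and a number 1.3 percentage points lower from compound 2 to compound 4 (within the scatter), so a nitrile on either of these two ring positions leaves the number with that low group, and only compound 3 stands apart. Nothing here explains that gap.

As far as these compounds go, it remains open whether methoxy would keep this level elsewhere on the phenyl ring. From the compounds shown here alone, whether an amine or a carboxylic acid on that ring could match compound 3 is also open.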